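Ethoxy Extension on the Ether Side Chain

A few compounds are considered here, and "the series" means these few. Any claim that something is new, unique, unknown or untested is made for them only; others in the source may bear on it.

Compound 1 `CC(C)Oc1cccc2ccc(N)nc12` gives 437 nM in an assay on cells with melanin-concentrating hormone receptor 1 (Homo sapiens) as the target, read by radioligand binding (a higher number here means a weaker inhibitor, a lower number a stronger inhibitor), the higher of the two numbers measured there, while compound 2 `Nc1ccc2cccc(OC3CCCCCC3)c2n1` gives 137 nM in this assay, a gap beyond the usual scatter. Compound 3 `CC(CC(C)(C)C)Oc1cccc2cccnc12` reaches only a limit in this assay, > 2000 nM, as noted in the limit of > 2000 nM in this assay, at which 1 of the 3 values shown sits. Compound 4 `CCOCC(C)Oc1cccc2ccc(N)nc12` differs from compound 1 by ethoxy in place of hydrogen on a saturated chain carbon, two bonds along the chain from an oxygen on an aromatic ring. Among the compounds with values here, no measured pair isolates this change, and compound 3, which also lacks the amino group, does not speak to it directly. The author expects the step from compound 1 to compound 4 in this assay, a 1.2-fold lower number from compound 1 to compound 4 (0.10 log units; within the scatter), to stay within the scatter. Compound 4 is therefore estimated at 350 nM, between 120 nM and 1000 nM.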

Compound 4, half-maximal inhibitory concentration: 1070 nM
Estimate against measurement, compound 4: 3.1-fold (0.49 log units) below, and the stated range ends below it.
By their numbers in this assay, from the lowest: compound 2; then compound 1; then compound 4. At a limit, above all of these: compound 3.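

Placing ethoxy on this saturated chain carbon gives a 2.4-fold higher number from compound 1 to compound 4 (0.39 log units; beyond the scatter) in this assay, the first change in one place among the compounds shown. At this position, then, the added ethoxy weakens the compound rather than leaving its number unchanged. Nothing in the data shown accounts for this step.

The compounds shown leave open whether the step goes with the oxygen of the ethoxymethyl chain or with its length. They also leave open how a longer chain of carbon alone, or an amine, would read at this carbon.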